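Chloro for methyl on a spirooxindole-chromone scaffold

The source may hold more compounds than are shown below. What is called first, only, known or untested is meant among the compounds shown, and "the series" means these compounds.

Measured compounds:
compound 1, `Cc1ccc2c(c1)C1(C(=O)N2C)C(C#N)=C(N)Oc2cc3oc(-c4ccccc4)cc(=O)c3c(O)c21`: > 50000 nM
compound 2, `CN1C(=O)C2(C(C#N)=C(N)Oc3cc4oc(-c5ccccc5)cc(=O)c4c(O)c32)c2cc(Cl)ccc21`: 21400 nM
compound 3, `Cc1cccc2c1N(Cc1ccccc1)C(=O)C21C(C#N)=C(N)Oc2cc3oc(-c4ccccc4)cc(=O)c3c(O)c21`: > 50000 nM

In a functional assay on PC-3 cells (Homo sapiens) for antiproliferative activity, read by MTT assay, with a stated time of 48 h (a lower number here means a stronger inhibitor, a higher number a weaker inhibitor), compound 1 reaches only a limit, > 50000 nM. Compound 2 gives 21400 nM in this assay. The change between them, (chloro in place of methyl on an aromatic carbon), produced an at least 2.3-fold lower number from compound 1 to compound 2 (0.36 log units; beyond the scatter). Compound 3 likewise returns only a limit in this assay, > 50000 nM; how its core differs from that of compound 1 is not broken down here. Compound 4, `N#CC1=C(N)Oc2cc3oc(-c4ccccc4)cc(=O)c3c(O)c2C12C(=O)N(Cc1ccccc1)c1c(Cl)cccc12`, is not yet measured in this assay. It differs from compound 3 by chloro in place of methyl on an aromatic carbon, the same kind of change as from compound 1 to compound 2, though the substituent now sits ortho to a fused ring and meta to a fused ring rather than meta and para to one. Because (the limit of > 50000 nM in this assay, at which 2 of the 3 values shown sit), the earlier step can only be read as a minimum. Compound 4 is expected to show an at least 1.6-fold lower number from compound 3 to compound 4 (0.22 log units; that floor lies within the scatter), resting on that step. The estimate for compound 4 is 30000 nM, between 12000 nM and 80000 nM.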

Compound 4, half-maximal inhibitory concentration: > 50000 nM
Compound 4 gave a limit, no number (the forecaster's own chance of this, stated with the estimate: 45%); middle value at least 1.6-fold (0.22 log units) from the limit.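

Compound 3 and compound 4 both return only a limit in this assay, so no step between them can be read: the limit of > 50000 nM in this assay, at which 3 of the 4 values shown sit.

The compounds shown leave open whether chloro in place of methyl, ortho to a fused ring and meta to a fused ring, lowers the number on the core of compound 3 as it did for an at least 2.3-fold lower number from compound 1 to compound 2 (0.36 log units; beyond the scatter).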